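The source may hold more compounds than are shown below. What is called first, only, known or untested is meant among the compounds shown, and "the series" means these compounds.

Measured in a functional assay on SH-SY5Y cells (Homo sapiens) for cytotoxicity, read by MTT assay, with a stated time of 48 h; on this read-out higher numbers stand for weaker inhibition and lower numbers for stronger inhibition:
compound 1, `CC(c1nccs1)C(C#N)(C#N)CCC(F)=C(F)F`, only a limit, > 120000 nM
compound 2, `FC(F)=C(F)CCSc1nccs1`, only a limit, > 120000 nM
compound 3, `FC(F)=C(F)CCSc1nnc(S)s1`, only a limit, > 120000 nM

Compound 2 stands at the limit of this assay, as do the other two measured compounds: the limit of > 120000 nM in this assay, at which 3 of the 3 values shown sit. Among the compounds with values here, no step between measured compounds is available, so no size of step can be read from the series itself. Compound 4, `FC(F)=C(F)CCSc1ncc(-c2ccncc2)s1`, differs from compound 2 by pyridin-4-yl in place of hydrogen on an aromatic carbon. With every measured compound sitting at the limit, the step expected a step that the limit leaves unreadable from compound 2 to compound 4 is none beyond the scatter, most likely again a limit. Compound 4 is therefore expected at 150000 nM, with a range from 40000 nM to 600000 nM.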

Compound 4, half-maximal inhibitory concentration: > 120000 nM
Compound 4: a limit, no number; the forecaster's own chance of this, stated with the estimate: 70%; the middle value lies beyond the limit too.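

No step can be read from compound 2 to compound 4, because both values are limits: the limit of > 120000 nM in this assay, at which 4 of the 4 values shown sit.

The compounds shown leave open what concentration gives half-maximal inhibition in this assay for any of them, and so what pyridin-4-yl in place of hydrogen changes.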